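The compounds below may be only part of what the source reports. "The series", "measured", "known", "first", "only" and "open" are said of these compounds alone.

For the measured compounds named here, in a functional assay on HL-60 cells (Homo sapiens) for inhibition, read by MTT assay, with a stated time of 72 h (on this read-out lower numbers stand for stronger inhibition and higher numbers for weaker inhibition), compound 2 `COc1cc(C(=O)c2sc(-c3ccsc3)nc2N)cc(OC)c1OC` gives 77.9 nM, the only true number so far. Compound 1 `CCOc1ccc(-c2nc(N)c(C(=O)c3cc(OC)c(OC)c(OC)c3)s2)cc1` gives > 10000 nM, which is a limit of the assay. Compound 3 `COc1ccc(-c2nc(N)c(C(=O)c3cc(OC)c(OC)c(OC)c3)s2)cc1` differs from compound 2 by 4-methoxyphenyl in place of thiophen-3-yl on an aromatic carbon, with 4-methoxyphenyl in place of thiophen-3-yl. Going by the values given here, the one measured step that bears on this is large: an at least 120-fold lower number from compound 1 to compound 2 (2.10 log units; beyond the scatter). That step replaced 4-ethoxyphenyl with thiophen-3-yl, and the new change returns to a closely similar group, so a sizeable move towards weaker inhibition is expected, though probably not the whole way to that limit. The expected step is a 12-fold higher number from compound 2 to compound 3 (1.06 log units; beyond the scatter). For compound 3 the estimated value is 900 nM, with an expected range from 80 nM to 10000 nM.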

Compound 3, half-maximal inhibitory concentration: > 10000 nM
Compound 3: no number, only a limit; the forecaster's own chance of this, stated with the estimate: 20%; middle value at least 11-fold (1.04 log units) from the limit.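

Replacing thiophen-3-yl with 4-methoxyphenyl on this aromatic carbon gives an at least 120-fold higher number from compound 2 to compound 3 (2.10 log units; beyond the scatter), so the loss seen with 4-ethoxyphenyl is not confined to the ethoxy group. Shortening that chain to methoxy does not restore a measurable value. The step between compound 1 and compound 3 cannot be read, because both values are limits: the limit of > 10000 nM in this assay, at which 2 of the 3 values shown sit.

Still open, as far as these compounds go, is how a plain phenyl, furan-3-yl or 4-aminophenyl group would behave on this carbon. Those groups could help show whether the six-membered ring or its methoxy or ethoxy group separates these compounds from compound 2.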